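The source may report more compounds than this note shows. Statements on the series, on what has been measured and on what is new or still open speak of the compounds shown alone.

Series notes, amide side chain and benzyl nitrile.

Compound 1 `COC(=O)[C@H](CCSC)NC(=O)c1ccc(NCc2cncn2Cc2ccc(C#N)cc2)cc1-c1ccccc1` is the reference. In a functional assay on NIH3T3 cells (Mus musculus) (on this read-out lower numbers stand for an effect already at smaller amounts and higher numbers for an effect only at larger amounts of compound), compound 1 gives only a limit of the assay, > 10 uM, and no number. Compound 2 `CSCNC(=O)c1ccc(NCc2cncn2Cc2ccc(C#N)cc2)cc1-c1ccccc1` carries (methylsulfanyl)methyl on the amide-type nitrogen. In this assay compound 2 likewise gives only a limit, > 10 uM. Compound 3 `N#Cc1ccc(Cn2cncc2CNc2ccc(C(=O)NCC3CCCCC3)c(-c3ccccc3)c2)cc1` carries cyclohexylmethyl on the same nitrogen. In this assay compound 3 also gives only a limit, > 10 uM. The steps among these three are accordingly not readable: a step that the two limits leave unreadable from compound 1 to compound 2, a step that the two limits leave unreadable from compound 1 to compound 3 and a step that the two limits leave unreadable from compound 2 to compound 3. All three values sit at the same point, (the limit of > 10 uM in this assay, at which 3 of the 3 values shown sit).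

Compound 4 `COC(=O)[C@H](CCSC)NC(=O)c1ccc(NCc2cncn2Cc2ccccc2C#N)cc1-c1ccccc1` differs from compound 1 elsewhere, on the saturated chain carbon bound to an aromatic nitrogen: 2-cyanophenyl in place of 4-cyanophenyl on a saturated chain carbon bound to an aromatic nitrogen. Cut one bond further out this reads 4-cyanobenzyl to 2-cyanobenzyl. Going by the values given here, none of the measured steps touches this part of the molecule; the three measured steps all vary the amide side chain, and none of them gives a size. Nothing measured therefore points to a gain on moving the nitrile within the benzyl ring, and compound 4 is expected to sit near the same limit, with a step that the limit leaves unreadable from compound 1 to compound 4. Compound 4 is estimated at 15 uM, within 4 uM to 60 uM.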

Compound 4, concentration for half-maximal effect: > 10 uM
Compound 4 gave a limit, no number; the forecaster's own chance of this, stated with the estimate: 75%; the middle value lies beyond the limit too.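

In this assay compound 4 gives only a limit of the assay, > 10 uM. No step can be read between compound 1 and compound 4, and all values shown stand at one point: the limit of > 10 uM in this assay, at which 4 of the 4 values shown sit.

The compounds shown leave open whether 4-cyanobenzyl and 2-cyanobenzyl differ at all, and what any of the amide side chains contributes to the effect.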